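Moving a methoxy group on an amide-bearing ring

The source may hold more compounds than are shown below. What is called first, only, known or untested is meant among the compounds shown, and "the series" means these compounds.

Compound 1 `COc1ccccc1C(=O)NCc1ccc(CNS(=O)(=O)c2ccccc2)cc1` has the lowest number of the three measured compounds in an assay on MDA-MB-231 cells for binding affinity to C-X-C chemokine receptor type 4 (Homo sapiens), read by immunofluorescence and microscopy, with stated times of 10 min and 30 min (on this read-out lower numbers stand for an effect already at smaller amounts and higher numbers for an effect only at larger amounts of compound), giving 1 nM. Compound 2 `COc1ccccc1C(=O)NCc1ccc(CNS(=O)(=O)c2ccc(C)cc2)cc1` gives 100 nM and compound 3 `Cc1ccc(S(=O)(=O)NCc2ccc(CNC(=O)c3ccccc3C)cc2)cc1` gives 100 nM in this assay. The step of a 100-fold higher number from compound 1 to compound 2 (2.00 log units; beyond the scatter) shows that adding a methyl to the sulfonyl-bearing ring costs a great deal, while no change at the digits printed from compound 2 to compound 3 (within the scatter) shows that swapping methoxy for methyl on the amide-bearing ring is tolerated.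

Compound 4 `COc1cccc(C(=O)NCc2ccc(CNS(=O)(=O)c3ccccc3)cc2)c1` differs from compound 1 only in the position of the methoxy group: 3-methoxyphenyl in place of 2-methoxyphenyl on a carbonyl carbon. Neither measured step moves a group from one spot to another on the same ring, so no direct guide exists for this change. The result from compound 2 shows that a small change on one ring can matter greatly, whereas compound 3 shows a change on the amide-bearing ring passing unnoticed. For compound 4 a modest weakening is therefore expected, roughly a 10-fold higher number from compound 1 to compound 4 (1.00 log units; beyond the scatter). Compound 4 is estimated at 10 nM, in a range of 1 nM to 100 nM.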

Compound 4, effective concentration (reported as EC, without a stated level of effect): > 1000 nM
Compound 4 gave a limit, no number; the forecaster's own chance of this, stated with the estimate: 5%; at least 100-fold (2.00 log units) between middle value and limit.
By their numbers in this assay, from the lowest: compound 1; then compounds 2 and 3 (each within the scatter of the next). At a limit, above all of these: compound 4.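

Moving the methoxy group, with 3-methoxyphenyl in place of 2-methoxyphenyl on a carbonyl carbon, gives an at least 1000-fold higher number from compound 1 to compound 4 (3.00 log units; beyond the scatter), even though the two compounds contain the same atoms. The amide-bearing ring is therefore far from indifferent to change: where the methoxy group sits can matter greatly, something that no change at the digits printed from compound 2 to compound 3 (within the scatter), a swap of one group for another, gave no sign of. Compound 4 stands at a limit, not a number, in this assay: the limit of > 1000 nM in this assay, at which 1 of the 4 values shown sits.

As far as these compounds go, what stays open is how an ethoxy group, a hydroxyl group or an amine would fare in place of the methoxy group of compound 1. Also open, from the compounds shown here alone, is whether the same move of the methoxy group would cost as much in compound 2, which carries a methyl on its sulfonyl-bearing ring.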